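A few compounds are considered here, and "the series" means these few. Any claim that something is new, unique, unknown or untested is made for them only; others in the source may bear on it.

Measured in a functional assay on HT-29 cells (Homo sapiens) for inhibition, read by luminescence and CellTiter-Glo, with a stated time of 24 h; a lower number here means that less compound is needed, a higher number that more compound is needed for the effect:
- Compound 1 `CN1C(=S)[C@@H](NC(=O)c2nc(Cc3ccccc3)n(C)n2)COc2ccccc21` at 2.5 nM
- Compound 2 `CCCCCn1nc(C(=O)N[C@H]2COc3ccccc3N(C)C2=S)nc1Cc1ccccc1` at 805 nM
- Compound 3 `CC(C)n1nc(C(=O)N[C@H]2COc3ccccc3N(C)C2=S)nc1Cc1ccccc1` at 360 nM

Compound 3 has the second highest of these three numbers. It lies close to compound 2 and far from compound 1. The next compound, compound 4 `COCCn1nc(C(=O)N[C@H]2COc3ccccc3N(C)C2=S)nc1Cc1ccccc1`, has not yet been measured. It carries 2-methoxyethyl in place of isopropyl on an aromatic nitrogen.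

Three measured steps change the group on that same aromatic nitrogen. Replacing the methyl of compound 1 with isopropyl gives a 140-fold higher number from compound 1 to compound 3 (2.16 log units; beyond the scatter), a large step, and the pentyl group of compound 2 gives a 320-fold higher number from compound 1 to compound 2 (2.51 log units; beyond the scatter), also large. Between the two larger groups the change is only modest, at a 2.2-fold lower number from compound 2 to compound 3 (0.35 log units; beyond the scatter). Among these three compounds, then, the big loss separates methyl from both larger chains, while isopropyl and pentyl stay fairly close. The 2-methoxyethyl group is also larger than methyl, so compound 4 is expected to sit near compound 3 and compound 2, not near compound 1. However, no measured compound has an oxygen in this chain, so the uncertainty is wide.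

The expected step is small and without a firm direction, estimated as a 1.2-fold lower number from compound 3 to compound 4 (0.08 log units; within the scatter). For compound 4 the estimated value is 300 nM, with an expected range from 70 nM to 1000 nM.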

Compound 4, half-maximal effective concentration: 566 nM
Compound 4: the middle estimate sits 1.9-fold (0.28 log units) below what was measured; low and high end bracket the measured number.
By their numbers in this assay, from the lowest: compound 1; then compounds 3, 4 and 2 (each within the scatter of the next, the first and the last beyond it).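

In this assay, the 2-methoxyethyl chain on the aromatic nitrogen brings an oxygen and a hydrogen-bond acceptor to this position, yet compound 4 cannot be told apart from either chain that holds only carbon: the result is a 1.6-fold higher number from compound 3 to compound 4 (0.20 log units; within the scatter) and a 1.4-fold lower number from compound 2 to compound 4 (0.15 log units; within the scatter) in this series. The change from methyl remains large, at a 230-fold higher number from compound 1 to compound 4 (2.35 log units; beyond the scatter) relative to the core of compound 1, so among these four compounds the oxygen does nothing to close the gap that separates methyl from the three larger groups. The data on hand offer no explanation for this result.

The compounds shown leave open how the number moves between methyl and isopropyl, since an ethyl or a cyclopropyl group on this nitrogen would show whether the large loss sets in at once or gradually. They also leave open whether a chain ending in an amine, a hydroxyl or a carboxylic acid would stay with compounds 2, 3 and 4, or instead come closer to compound 1.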